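Thiazolyl amine to benzimidazolyl amine in kinetic solubility

The compounds below may be only part of what the source reports. "The series", "measured", "known", "first", "only" and "open" are said of these compounds alone.

Of the compounds shown here, three sharing one core have been measured in a physicochemical assay for solubility, read by chemiluminescence, in phosphate buffer, measured as kinetic solubility, at pH 7.4; a lower number here means a less soluble compound, a higher number a more soluble compound. In this assay compound 1 `Cc1cc(C)n(-c2ccc(C(=O)NCC3(c4nc(-c5ccccc5)cs4)CCOCC3)cc2)n1` gives 33000 nM. Compound 2 `Cn1ccc(Nc2ccc(C(=O)NCC3(c4nc(-c5ccccc5)cs4)CCOCC3)cc2)n1` gives 48000 nM, and the step of a 1.5-fold higher number from compound 1 to compound 2 (0.16 log units; within the scatter) lies within the scatter. Compound 3 `Cc1cnc(Nc2ccc(C(=O)NCC3(c4nc(-c5ccccc5)cs4)CCOCC3)cc2)s1` gives < 1000 nM, which is a limit of the assay and not a number (the limit of < 1000 nM in this assay, at which 1 of the 3 values shown sits). Compound 3 therefore stands at the bottom of the range covered here, reached through the two large steps of an at least 33-fold lower number from compound 1 to compound 3 (1.51 log units; beyond the scatter) and an at least 48-fold lower number from compound 2 to compound 3 (1.68 log units; beyond the scatter).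

Compound 4 `Cn1c(Nc2ccc(C(=O)NCC3(c4nc(-c5ccccc5)cs4)CCOCC3)cc2)nc2ccccc21` has not yet been measured. Its difference from compound 3 is 1-methyl-1H-benzimidazol-2-yl in place of 5-methyl-1,3-thiazol-2-yl on a nitrogen on an aromatic ring. Among the compounds with values here, no measured step covers this exact exchange. Within the data shown here, the steps that bear on the same position, an at least 33-fold lower number from compound 1 to compound 3 (1.51 log units; beyond the scatter) and an at least 48-fold lower number from compound 2 to compound 3 (1.68 log units; beyond the scatter), both ran sharply downward once the 5-methyl-1,3-thiazol-2-yl group was in place. Because compound 3 gives < 1000 nM and so offers only a limit, the direction of the expected step that the limit leaves unreadable from compound 3 to compound 4 cannot be fixed. Compound 4 is therefore expected to stay near or under that limit, estimated at 800 nM, in a range from 200 nM to 3000 nM.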

Compound 4, solubility: 10000 nM
For compound 4 the middle estimate is 13-fold (1.10 log units) below the measured one; the whole stated range lies below it.
By their numbers in this assay, from the lowest: compound 4; then compounds 1 and 2 (each within the scatter of the next). At a limit, below all of these: compound 3.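

Exchanging the 5-methyl-1,3-thiazol-2-yl group for 1-methyl-1H-benzimidazol-2-yl on a nitrogen on an aromatic ring gives, in this assay, an at least 10-fold higher number from compound 3 to compound 4 (1.00 log units; beyond the scatter), so the amino link in itself does not hold a compound at the bottom of the range. The new group does not fully match the earlier groups either, with a 4.8-fold lower number from compound 2 to compound 4 (0.68 log units; beyond the scatter) and a 3.3-fold lower number from compound 1 to compound 4 (0.52 log units; beyond the scatter), both modest steps. The reading for compound 3 is a limit and not a number, so the full size of the step from it stays unknown: the limit of < 1000 nM in this assay, at which 1 of the 4 values shown sits.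

The compounds shown leave open whether the low reading of compound 3 goes with the thiazole ring or with its methyl group, which a plain 1,3-thiazol-2-yl group would separate. They also leave open how far a carboxylic acid or an amine on the 1-methyl-1H-benzimidazol-2-yl group would shift the reading.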